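Compound 1 to compound 3: hydroxy to ester

The source may hold more compounds than are shown below. What is called first, only, known or untested is meant among the compounds shown, and "the series" means these compounds.

In a functional assay on HT-29 cells (Homo sapiens) for cytotoxicity, read by MTT assay, with a stated time of 48 h (a lower number here means a stronger inhibitor, a higher number a weaker inhibitor), compound 1 (`C=C1C(=O)O[C@H]2[C@H]1[C@@H](OC(=O)/C(C)=C/C)C[C@@](C)(O)[C@]13C=C[C@](C)([C@H]21)[C@]1(C3)C(=O)O[C@@H]2[C@H]3C(C)=CC[C@H]3[C@](C)(O)C[C@H](O)[C@H]21`) gives > 10000 nM as a limit and not a number. Compound 2 (`C=C1C(=O)O[C@H]2[C@H]1[C@@H](O)C[C@@](C)(O)[C@]13C=C[C@](C)([C@H]21)[C@]1(C3)C(=O)O[C@@H]2[C@H]3C(C)=CC[C@H]3[C@](C)(O)C[C@H](OC(=O)/C(C)=C\C)[C@H]21`) gives > 10000 nM as a limit too. Compound 3 (`C=C1C(=O)O[C@H]2[C@H]1[C@@H](OC(=O)/C(C)=C/C)C[C@@](C)(O)[C@]13C=C[C@](C)([C@H]21)[C@]1(C3)C(=O)O[C@@H]2[C@H]3C(C)=CC[C@H]3[C@](C)(O)C[C@H](OC(=O)/C(C)=C/C)[C@H]21`) differs from compound 1 by (1-methylprop-1-en-1-yl)carbonyl in place of hydrogen on an oxygen on a saturated carbon with (1-methylprop-1-en-1-yl)carbonyl in place of hydrogen on an oxygen on a saturated carbon. Going by the values given here, no measured step is available to size this change. The estimated step that the limit leaves unreadable from compound 1 to compound 3 is expected to stay within the scatter in this assay with no clear direction. For compound 3 the expected value is 12000 nM with 4000 nM to 30000 nM as the estimated range.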

Compound 3, half-maximal inhibitory concentration: 9600 nM
For compound 3 the middle estimate is 1.3-fold (0.10 log units) above the measured one, within the range that was stated.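

With (1-methylprop-1-en-1-yl)carbonyl in place of hydrogen on this oxygen, compound 3 gives a true number in this assay: 9600 nM. The step is an at least 1.0-fold lower number from compound 1 to compound 3 (0.01 log units; that floor lies within the scatter), so the ester here establishes no gain. Its true size stays unread because compound 1 is held at a limit, as is one other compound: the limit of > 10000 nM in this assay, at which 2 of the 3 values shown sit.

Open, from the compounds shown here alone, is whether a smaller acetyl ester, a longer acyl chain or an amine on this oxygen would give a step beyond the scatter. Also open, going by these compounds, is how a free carboxylic acid in that ester chain would read.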